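The compounds below may be only part of what the source reports. "The series", "measured", "known", "first", "only" and "open" are said of these compounds alone.

Working notes on the series. The shared core carries a 4-methylpiperazin-1-yl group next to the varied aromatic nitrogen. Compound 1 `C#CCOCCn1c(N2CCN(C)CC2)nc2ccccc21` gives 12 nM in a functional assay on ileum for inhibition of histamine H1 receptor (Cavia porcellus); on this read-out higher numbers stand for weaker inhibition and lower numbers for stronger inhibition. Among the measured compounds shown here, compound 2 `CCCC(C)n1c(N2CCN(C)CC2)nc2ccccc21` gives 1400 nM in this assay, the highest of the two numbers so far, and the single measured step, a 120-fold higher number from compound 1 to compound 2 (2.07 log units; beyond the scatter), separates it from compound 1.

Compound 3 `CCCn1c(N2CCN(C)CC2)nc2ccccc21` is not yet measured; it differs from compound 2 by propyl in place of 1-methylbutyl on an aromatic nitrogen. For the measured compounds named here, no measured pair traces an exchange of one plain alkyl chain for another, so the known step of a 120-fold higher number from compound 1 to compound 2 (2.07 log units; beyond the scatter), which concerns a different kind of substituent, sets only a rough scale. Both 1-methylbutyl and propyl are plain alkyl chains, and the expected movement in this assay for compound 3 is modest, more likely toward a lower number than a higher one, with wide uncertainty. The expected step from compound 2 to compound 3 is a 2.3-fold lower number from compound 2 to compound 3 (0.37 log units; beyond the scatter). For compound 3 the estimated value in this assay is 600 nM, with a range from 150 nM to 3000 nM.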

Compound 3, half-maximal inhibitory concentration: 380 nM
Compound 3: middle estimate off by 1.6-fold (0.20 log units), on the high side; the range from low to high includes it.
By their numbers in this assay, from the lowest: compound 1; then compound 3; then compound 2.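

Within the plain alkyl chains on the aromatic nitrogen, this assay still responds to the exchange, with a 3.7-fold lower number from compound 2 to compound 3 (0.57 log units; beyond the scatter), so this position is sensitive to more than the loss of the propargyloxy end of the chain. The large gap to the 2-(propargyloxy)ethyl chain also persists with a second alkyl group, at a 32-fold higher number from compound 1 to compound 3 (1.50 log units; beyond the scatter), so it does not depend on 1-methylbutyl alone, and neither alkyl compound comes close to compound 1. No measurement of any property is available to account for either step.

The exchange of 1-methylbutyl for propyl shortens the chain and removes its branch in one move, so the compounds shown cannot separate the two changes; a straight pentyl chain on the same nitrogen would bear on that question. Also open, as far as these compounds go, is which part of the 2-(propargyloxy)ethyl chain goes with the low number of compound 1, the ether oxygen or the terminal alkyne, and a 2-methoxyethyl chain or a pent-4-ynyl chain at this position would begin to address it.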